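Oxazolidinedione to thiazolidinedione: solubility at acidic pH

This account rests on a few compounds, and the source may have more. Where it says the series, first, only, none or still open, it means among the compounds named here.

Measured compounds:
compound 1 `CC(C)[C@H](C[C@H]1OC(=O)NC1=O)c1ccc(-c2ccc3cccc(F)c3c2)[nH]c1=O`, 24400 nM
compound 2 `O=C1NC(=O)/C(=C/C2(c3ccc(-c4ccc5cccc(F)c5c4)[nH]c3=O)CC2)O1`, 27400 nM

Of the compounds shown here, two of the shared core have been tested in a physicochemical assay for solubility, measured as kinetic solubility, at pH 2; on this read-out higher numbers stand for higher solubility and lower numbers for lower solubility. Compound 1 `CC(C)[C@H](C[C@H]1OC(=O)NC1=O)c1ccc(-c2ccc3cccc(F)c3c2)[nH]c1=O` gives 24400 nM in this assay. Compound 2 `O=C1NC(=O)/C(=C/C2(c3ccc(-c4ccc5cccc(F)c5c4)[nH]c3=O)CC2)O1` gives 27400 nM in this assay. The two numbers lie within the usual scatter of each other, so nothing separates compound 1 from compound 2 on this read-out, and compound 1 simply stands beside compound 2.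

Compound 3 `CC(C)[C@H](C[C@H]1SC(=O)NC1=O)c1ccc(-c2ccc3cccc(F)c3c2)[nH]c1=O` has not been measured. It differs from compound 1 in one place: 2,4-dioxo-1,3-thiazolidin-5-yl in place of 2,4-dioxo-1,3-oxazolidin-5-yl on a saturated chain carbon, two bonds along the chain from an aromatic carbon. Going by the values given here, no measured pair of this study shows the same change, so there is no step to lean on. With only the near-identical numbers of compound 1 and compound 2 as background, the step from compound 1 to compound 3 in this assay is expected to be small, at most a modest move downward, and possibly none beyond the scatter; the expected step is a 1.4-fold lower number from compound 1 to compound 3 (0.13 log units; within the scatter). For compound 3 the estimated value in this assay is 18000 nM, within a range from 8000 nM to 40000 nM.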

Compound 3, solubility: 4900 nM
Estimate against measurement, compound 3: 3.7-fold (0.57 log units) above; the measured number lies below the stated range.
By their numbers in this assay, from the lowest: compound 3; then compounds 1 and 2 (each within the scatter of the next).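

In this assay, putting 2,4-dioxo-1,3-thiazolidin-5-yl in place of 2,4-dioxo-1,3-oxazolidin-5-yl on a saturated chain carbon, two bonds along the chain from an aromatic carbon, gives a 5.0-fold lower number from compound 1 to compound 3 (0.70 log units; beyond the scatter), a step beyond the scatter. Going by these compounds alone, the two groups have the same count of heavy atoms, hydrogen-bond donors and acceptors, the same lack of net charge and one defined stereocentre each, yet exchanging one ring oxygen for sulfur at this position is enough to move this read-out, which the earlier compounds, with no single-place step between them, could not show. Nothing measured here accounts for the size of this step.

From the compounds shown here alone, it remains open whether the same exchange would give a step of similar size on the ring of compound 2, since this is a single pair at a single position. Also open, going by these compounds, is how a carboxylic acid, a tetrazole or an amine at this chain carbon, in place of either five-membered ring, would stand in this assay.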